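This account rests on a few compounds, and the source may have more. Where it says the series, first, only, none or still open, it means among the compounds named here.

Measured compounds:
- compound 1 `COc1ncc(-c2ccc3ncnc(Nc4ccc(OCCO)c(F)c4)c3c2)cc1NS(=O)(=O)c1ccc(F)cc1F` — 4820 nM
- compound 2 `COc1ncc(-c2ccc3ncnc(Nc4ccc(OCCO)nc4)c3c2)cc1NS(C)(=O)=O` — 3080 nM

In a functional assay on MCF7 cells (Homo sapiens) for antiproliferative activity, read by sulforhodamine B assay, with a stated time of 72 h (on this read-out lower numbers stand for stronger inhibition and higher numbers for weaker inhibition), compound 1 gives 4820 nM. Of the two numbers shown, that of compound 1 is the higher, but compound 2 with 3080 nM lies within the usual scatter of it, so the two cannot be told apart on this read-out, and compound 2 differs from compound 1 in more than one place, so no single step can be drawn between them.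

Compound 3 `COc1cc(Nc2ncnc3ccc(-c4cnc(OC)c(NS(=O)(=O)c5ccc(F)cc5F)c4)cc23)ccc1OCCO` shares the core of compound 1 and differs from it in one place: methoxy in place of fluoro on an aromatic carbon. Among the measured compounds shown here, no measured pair here shows what such an exchange does on this assay, so the expectation rests on the structural change alone, which is small in size and leaves the rest of the molecule untouched. Compound 3 is therefore expected to sit close to compound 1, with a step of a 1.4-fold lower number from compound 1 to compound 3 (0.14 log units; within the scatter) that does not clearly exceed the scatter in either direction. On that basis compound 3 is estimated at 3500 nM, with a range from 1200 nM to 10000 nM.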

Compound 3, half-maximal inhibitory concentration: 2260 nM
Beside the measured number, compound 3's estimate is 1.5-fold (0.19 log units) above it; measured number inside the range.
By their numbers in this assay, from the lowest: compounds 3, 2 and 1 (each within the scatter of the next, the first and the last beyond it).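

In this assay, among the compounds shown here, methoxy in place of fluoro on the aromatic carbon ortho to a 2-hydroxyethoxy group gives a 2.1-fold lower number from compound 1 to compound 3 (0.33 log units; beyond the scatter), a modest change but the first single-place step in this set, since compound 1 and compound 2 differ in more than one place. It shows that this position can register a change on this read-out and that the number does not worsen when methoxy, with 2 heavy atoms and 1 hydrogen-bond acceptor, replaces fluoro, with 1 heavy atom and 0 hydrogen-bond acceptors. No measurement here accounts for the size or direction of this step.

Going by these compounds, whether an ethoxy group, a chlorine atom, an amine or a bare hydrogen on the same aromatic carbon would lower the number further or raise it remains open, so a single exchange cannot yet describe a trend at this position. On these data alone, it is also open whether methoxy in place of fluoro would give a similar step with other groups elsewhere on the shared core, as this result rests on one pair of compounds.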